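Replacing a Chlorinated Benzyl Group: Predicting Compound 4

The source may hold more compounds than are shown below. What is called first, only, known or untested is meant among the compounds shown, and "the series" means these compounds.

Three compounds with the same core have been tested in a functional assay on K562 cells (Homo sapiens) for antiproliferative activity, with a stated time of 72 h; on this read-out lower numbers stand for stronger inhibition and higher numbers for weaker inhibition:

Compound 1 `OC[C@H]1O[C@@H](n2cnc3c(NCc4ccc(Cl)cc4)ncnc32)[C@H](O)[C@@H]1O` gives 218000 nM.
Compound 2 `OC[C@H]1O[C@@H](n2cnc3c(NCc4ccccc4Br)ncnc32)[C@H](O)[C@@H]1O` gives 10000 nM.
Compound 3 `OC[C@H]1O[C@@H](n2cnc3c(NCc4cccc(O)c4O)ncnc32)[C@H](O)[C@@H]1O` gives 25800 nM.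

Compound 1 stands as the highest of the three numbers, that is, the weakest inhibitor: its nearest neighbour is compound 3, and its furthest is compound 2, both separated from it by steps beyond the scatter.

Compound 4 `Cc1cccc(CNc2ncnc3c2ncn3[C@@H]2O[C@H](CO)[C@@H](O)[C@H]2O)c1O` is not yet measured. It differs from compound 1 in one place: 2-hydroxy-3-methylphenyl in place of 4-chlorophenyl on a saturated chain carbon bound to a nitrogen on an aromatic ring

Going by the values given here, two measured steps bear on this change. Exchanging 4-chlorophenyl for a substituted phenyl group gave a 22-fold lower number from compound 1 to compound 2 (1.34 log units; beyond the scatter) and an 8.4-fold lower number from compound 1 to compound 3 (0.93 log units; beyond the scatter). The group entering compound 4 shares its 2-hydroxy substituent with the group in compound 3, so the step to compound 3 is the closer guide; the step to compound 2 shows that a different pattern on the ring can give an even larger gain. Compound 4 is therefore expected to show a clearly lower number than compound 1, of roughly the size seen for compound 3.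

For compound 4 the expected step is an 8.7-fold lower number from compound 1 to compound 4 (0.94 log units; beyond the scatter).
Compound 4 is estimated at 25000 nM, within a range from 8000 nM to 80000 nM.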

Compound 4, half-maximal inhibitory concentration: 18000 nM
Compound 4: the middle estimate sits 1.4-fold (0.14 log units) above what was measured; the measured number falls inside the stated range.
By their numbers in this assay, from the lowest: compounds 2, 4 and 3 (each within the scatter of the next, the first and the last beyond it); then compound 1.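

In this assay, the step of a 12-fold lower number from compound 1 to compound 4 (1.08 log units; beyond the scatter) adds a third replacement of 4-chlorophenyl that lowers the number, and none of the compounds shown goes against this pattern at this position. The step of a 1.4-fold lower number from compound 3 to compound 4 (0.16 log units; within the scatter) lies within the scatter, so in this pair methyl can stand in place of one hydroxy group on an aromatic carbon without a readable change in antiproliferative activity. The step of a 1.8-fold higher number from compound 2 to compound 4 (0.26 log units; within the scatter) also lies within the scatter, so 2-bromophenyl and 2-hydroxy-3-methylphenyl cannot be told apart here, even though their ring substituents differ.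

On these data alone, how a 2-chlorophenyl group, or a phenyl ring carrying an amine or a carboxylic acid, would behave at this position remains open, and so does whether the lower numbers depend on the substituents that enter or on the loss of 4-chlorophenyl itself. The data shown offer no independent measurement that accounts for any of these steps.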